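The source may report more compounds than this note shows. Statements on the series, on what has been measured and on what is new or still open speak of the compounds shown alone.

Compound 1 `c1ccc(CNc2nc(-c3cccs3)nc3ccccc23)cc1` gives 13000 nM in an assay on isolated protein for inhibition of phosphodiesterase 1 (Bos taurus); a lower number here means a stronger inhibitor, a higher number a weaker inhibitor. Compound 2 `c1ccc(CNc2nc(-c3ccncc3)nc3ccccc23)cc1` gives 7000 nM in this assay; the step of a 1.9-fold lower number from compound 1 to compound 2 (0.27 log units; within the scatter) stays within the scatter, so the two compounds stand level on the numbers in hand. Compound 3 `c1ccc(CNc2nc(-n3ccnc3)nc3ccccc23)cc1` carries 1H-imidazol-1-yl in place of pyridin-4-yl on an aromatic carbon. Among the measured compounds shown here, the only measured step, a 1.9-fold lower number from compound 1 to compound 2 (0.27 log units; within the scatter), is the one that bears on this change: it also exchanged one aromatic ring for another on an aromatic carbon, and it did not move the number beyond the scatter. No step beyond the scatter is therefore expected in this assay for compound 3 either. Compound 3 is estimated at 8000 nM, with a range of 3000 nM to 25000 nM, which means a 1.1-fold higher number from compound 2 to compound 3 (0.06 log units; within the scatter).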

Compound 3, half-maximal inhibitory concentration: 14000 nM
The estimate for compound 3 lay 1.8-fold (0.24 log units) below the measured number, within the range that was stated.
By their numbers in this assay, from the lowest: compounds 2, 1 and 3 (each within the scatter of the next).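

In this assay, the 1H-imidazol-1-yl group separates from neither earlier ring: a 2.0-fold higher number from compound 2 to compound 3 (0.30 log units; within the scatter) and a 1.1-fold higher number from compound 1 to compound 3 (0.03 log units; within the scatter) both stay within the scatter. At this carbon between two ring nitrogen atoms, three aromatic rings, including two five-membered rings and one six-membered ring, now stand level on the numbers in hand. Nothing on hand accounts for these numbers.

From the compounds shown here alone, all three groups here are aromatic rings, so it remains open whether a morpholine, a primary amine or a short alkyl chain at this carbon would move the number beyond the scatter. Also open, going by these compounds, is how replacing the benzylamino group with a longer chain would read against these values.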